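A few compounds are considered here, and "the series" means these few. Any claim that something is new, unique, unknown or untested is made for them only; others in the source may bear on it.

Values measured in a functional assay, read by spectrophotometry, with a stated time of 1 h (on this read-out lower numbers stand for stronger inhibition and higher numbers for weaker inhibition), are as follows
Compound 1 `Nc1ccccc1/N=C\c1cc(=O)oc2cc(OCc3ccccc3)cc(OCc3ccccc3)c12` gives 624000 nM 
Compound 2 `Nc1ccccc1/N=C\c1cc(=O)oc2cc(OCc3ccccc3)ccc12` gives 34600 nM 
Compound 3 `N/N=C\c1cc(=O)oc2cc(OCc3ccccc3)ccc12` gives "not active" (no number reported) 

Of the two numbers available, compound 1 holds the higher one, and compound 3 offers no number to set against it. The unmeasured compound 4 `O=c1cc(/C=N\Nc2ccc([N+](=O)[O-])cc2)c2c(OCc3ccccc3)cc(OCc3ccccc3)cc2o1` keeps the core of compound 1 and differs on a double-bonded nitrogen, where (4-nitrophenyl)amino in place of 2-aminophenyl on a double-bonded nitrogen applies, with (4-nitrophenyl)amino in place of 2-aminophenyl.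

Among the compounds with values here, the only measured step, an 18-fold lower number from compound 1 to compound 2 (1.26 log units; beyond the scatter), is large, but it is hydrogen in place of benzyloxy on an aromatic carbon, a different change at a different place. It therefore gives no direct guide here. Compound 2 and compound 3 do differ in the group on that nitrogen, yet compound 3 has no number, so no size can be read from that pair. Within the data shown here, with no measured step covering this change, no step beyond the scatter is expected in this assay, although the uncertainty is wide. The estimated change is a 1.6-fold lower number from compound 1 to compound 4 (0.19 log units; within the scatter) on this evidence. The estimated value for compound 4 is 400000 nM with an expected range from 60000 nM to 1500000 nM on this read-out.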

Compound 4, half-maximal inhibitory concentration: 97900 nM
Estimate against measurement, compound 4: 4.1-fold (0.61 log units) above; the range from low to high includes it.
By their numbers in this assay, from the lowest: compound 2; then compound 4; then compound 1.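

With the shared core held fixed in this assay, (4-nitrophenyl)amino in place of 2-aminophenyl on a double-bonded nitrogen gives a 6.4-fold lower number from compound 1 to compound 4 (0.80 log units; beyond the scatter). Within the data shown here, this is the first size that can be read for a change at this place, as the earlier pair that differs in the group on that nitrogen, compound 2 and compound 3, has a number on one side only. It shows that the number in this assay responds to this group and not only to the benzyloxy change seen earlier, although no measurement here explains the step.

The swap changes several things at once, since the entering group brings both a nitro group and an amino nitrogen, so the compounds shown cannot say which of these parts goes with the lower number, and a plain phenylamino group or a nitrile or carboxylic acid in place of the nitro group would be needed to separate them. They also leave open whether the same swap gives a step of similar size on the core of compound 2, which carries hydrogen in place of one benzyloxy group.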